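Side-chain change from compound 3 to compound 4

The source may report more compounds than this note shows. Statements on the series, on what has been measured and on what is new or still open speak of the compounds shown alone.

In a functional assay on HeLa cells (Homo sapiens) for cytotoxicity, read by MTT assay, with a stated time of 72 h (a lower number here means a stronger inhibitor, a higher number a weaker inhibitor), compound 1 `CC(C)(C)C1=CC(=O)C=C(NCC(=O)O)C1=O` gives 132000 nM, compound 2 `CC1=CCC[C@H]2[C@](C)(CC3=CC(=O)C=CC3=O)[C@@H](C)CC[C@]12C` gives 18100 nM and compound 3 `CC1=CCC[C@H]2[C@](C)(CC3=CC(=O)C=C(N[C@@H](CC(C)C)C(=O)O)C3=O)[C@@H](C)CC[C@]12C` gives 7720 nM, the lowest of the three numbers. Compound 4 `CSCC[C@H](NC1=CC(=O)C=C(C[C@]2(C)[C@@H](C)CC[C@]3(C)C(C)=CCC[C@@H]23)C1=O)C(=O)O` is still unmeasured. Its difference from compound 3 is (methylsulfanyl)methyl in place of isopropyl on a saturated chain carbon, two bonds along the chain from an amine nitrogen and a carbonyl carbon: isobutyl becomes 2-(methylsulfanyl)ethyl. Among the measured compounds shown here, the only measured step touching this part is a 2.3-fold lower number from compound 2 to compound 3 (0.37 log units; beyond the scatter), a modest one that installs the whole (1-carboxy-3-methylbutyl)amino group. For the measured compounds named here, no measured step varies the side chain itself, so no step beyond the scatter is expected in this assay, and no direction is favoured. The expected change is a 1.0-fold higher number from compound 3 to compound 4 (0.02 log units; within the scatter), within the scatter. For compound 4 the estimated value is 8000 nM, with an expected range of 4000 nM to 16000 nM.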

Compound 4, half-maximal inhibitory concentration: 13900 nM
For compound 4 the middle estimate is 1.7-fold (0.24 log units) below the measured one; low and high end bracket the measured number.
By their numbers in this assay, from the lowest: compounds 3, 4 and 2 (each within the scatter of the next, the first and the last beyond it); then compound 1.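

In this assay the only side-chain variation shown, (methylsulfanyl)methyl in place of isopropyl on this saturated chain carbon, gives a 1.8-fold higher number from compound 3 to compound 4 (0.26 log units; within the scatter), so this position tolerates the change from isobutyl to 2-(methylsulfanyl)ethyl without a step beyond the scatter. The (1-carboxy-3-(methylsulfanyl)propyl)amino group gives a 1.3-fold lower number from compound 2 to compound 4 (0.11 log units; within the scatter), whereas the (1-carboxy-3-methylbutyl)amino group gave a 2.3-fold lower number from compound 2 to compound 3 (0.37 log units; beyond the scatter). No available evidence explains these results.

From the compounds shown here alone, whether a side chain bearing an amine or a second carboxylic acid would produce a step beyond the scatter remains open. The same holds for a longer chain.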